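A few compounds are considered here, and "the series" means these few. Any claim that something is new, unique, unknown or untested is made for them only; others in the source may bear on it.

Measured so far in a functional assay on MDA-MB-231 cells (Homo sapiens) for inhibition, read by sulforhodamine B assay, with a stated time of 48 h; on this read-out higher numbers stand for lower toxicity in this test and lower numbers for higher toxicity in this test:
Compound 1 `O=C(CN1C(=O)N/C(=C/c2ccc(Cl)cc2)C1=O)Nc1cccc(C(F)(F)F)c1` gives < 100000 nM, a limit of the assay rather than a number.
Compound 2 `O=C(CN1C(=O)N/C(=C\C=C\c2ccccc2)C1=O)Nc1ccc(Cl)cc1` gives < 100000 nM, again a limit of the assay.
Compound 3 `COc1ccc(/C=C2/NC(=O)N(CC(=O)Nc3cc(C(F)(F)F)ccc3Cl)C2=O)cc1` gives < 100000 nM, also a limit of the assay.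

Compound 3 therefore stands where every value shown stands, namely at the limit of < 100000 nM in this assay, at which 3 of the 3 values shown sit. Among the compounds with values here, no two measured compounds differ in one place only, so no step size can be read from these numbers, and the spread of the three values cannot be judged beyond the fact that all sit at the same limit.

Compound 4 `COc1ccc(/C=C2/NC(=O)N(CC(=O)Nc3cccc(C(F)(F)F)c3)C2=O)cc1` is the next compound for this assay. It differs from compound 3 by hydrogen in place of chloro on an aromatic carbon, in words hydrogen in place of chloro on an aromatic carbon. Within the data shown here, the data give no measured step to size this change. The step to compound 4 is expected to be a step that the limit leaves unreadable from compound 3 to compound 4, none beyond the scatter. For compound 4 the estimate is 40000 nM, expected between 8000 nM and 100000 nM, with a real chance that only a limit is reported again.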

Compound 4, concentration lethal to 50% of the cells: < 100000 nM
Compound 4 gave a limit, no number (the forecaster's own chance of this, stated with the estimate: 65%); the middle value is on the limit's open side.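

No step can be read from compound 3 to compound 4 or from compound 1 to compound 4, because the values give limits rather than numbers: the limit of < 100000 nM in this assay, at which 4 of the 4 values shown sit.

The compounds shown leave open how large either change is in this assay and how the four compounds rank there.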